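A few compounds are considered here, and "the series" means these few. Any claim that something is new, unique, unknown or untested is made for them only; others in the source may bear on it.

Working notes on the series. Among the measured compounds shown here, in an ADME assay on HUVEC cells (Homo sapiens) for inhibition, read by CCK-8 assay, with a stated time of 24 h, in the presence of a further agent that is not named here (on this read-out lower numbers stand for stronger inhibition and higher numbers for weaker inhibition), compound 1 `Cc1ccccc1-n1cc(-c2ccc(/C=C3\C(=O)Nc4ccccc43)cc2)nn1` gives 14700 nM, the only exact number so far. Compound 2 `O=C1Nc2ccccc2/C1=C/c1ccc(-c2cn(-c3ccccc3Cl)nn2)cc1` is reported only as a limit, > 20000 nM. Its standing is therefore bounded rather than fixed: the limit of > 20000 nM in this assay, at which 1 of the 2 values shown sits.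

For the measured compounds named here, the one measured step is an at least 1.3-fold higher number from compound 1 to compound 2 (0.13 log units; that floor lies within the scatter), for chloro in place of methyl on an aromatic carbon. That figure is a floor and not a true size.

Compound 3 `O=C1Nc2ccccc2/C1=C/c1ccc(-c2cn(-c3cccc(Cl)c3)nn2)cc1` has the same atoms as compound 2, joined differently: 3-chlorophenyl in place of 2-chlorophenyl on an aromatic nitrogen. It carries 3-chlorophenyl in place of 2-chlorophenyl on an aromatic nitrogen. Going by the values given here, no measured step covers this exact swap, and the step into compound 2 bears on it only loosely.

The expectation leans on compound 1 at 14700 nM, so no step beyond the scatter is expected in this assay, and no direction is favoured. The expected step is an at least 1.1-fold lower number from compound 2 to compound 3 (0.04 log units; that floor lies within the scatter). A report as a limit is about as likely as a number. The estimate for compound 3 is 18000 nM, with an expected range of 8000 nM to 40000 nM.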

Compound 3, half-maximal inhibitory concentration: > 20000 nM
Compound 3 gave a limit, no number; the forecaster's own chance of this, stated with the estimate: 50%; middle value at least 1.1-fold (0.04 log units) away from the limit.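

Moving the chlorine from 2-chlorophenyl to 3-chlorophenyl on the aromatic nitrogen gives a second compound reported only as a limit in this assay, so the step between compound 2 and compound 3 cannot be read. Against the only exact value in the series, the change from 2-methylphenyl to 3-chlorophenyl reads as an at least 1.3-fold higher number from compound 1 to compound 3 (0.13 log units; that floor lies within the scatter), which is a floor and not a true size. Neither chlorophenyl compound therefore gives a number, and the readings at this position now gather at a single ceiling: the limit of > 20000 nM in this assay, at which 2 of the 3 values shown sit.

As far as these compounds go, whether the two chlorophenyl compounds differ at all remains open, as does whether any group at this position can give a value clearly apart from that of compound 1. A phenyl ring carrying an amine or a carboxylic acid in place of the chlorine would test whether this position can move the read-out beyond the scatter.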